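Isobutyl for tert-butyl on the carbamate, second core

The source may report more compounds than this note shows. Statements on the series, on what has been measured and on what is new or still open speak of the compounds shown alone.

Compound 1 `CC(C)(C)OC(=O)N1CCC(Oc2cc(Oc3ccc(/C=C4\SC(=O)NC4=O)cc3)ncn2)CC1` bears a tert-butoxycarbonyl group on the piperidine nitrogen, and in a functional assay on CHO-K1 cells for agonist activity at Glucose-dependent insulinotropic receptor (Homo sapiens), read by cAMP accumulation and immunoassay, with a stated time of 1 h (a lower number here means a smaller maximal response, a higher number a larger maximal response), compound 1 gives 122%. Compound 2 `CC(C)COC(=O)N1CCC(Oc2cc(Oc3ccc(/C=C4\SC(=O)NC4=O)cc3)ncn2)CC1` differs from it by isobutyl in place of tert-butyl on an oxygen next to a carbonyl group, and in this assay compound 2 gives 51%; the step is a number 71 percentage points lower from compound 1 to compound 2 (beyond the scatter). Compound 3 `CC(C)(C)OC(=O)N1CCC(Oc2cc(Oc3cccc(/C=C4\SC(=O)NC4=O)c3)ncn2)CC1` keeps the tert-butoxycarbonyl group but carries a different core; the difference between the two cores is not broken down here. In this assay compound 3 gives 78.3%, which lies below compound 1 and above compound 2. Compound 4 `CC(C)COC(=O)N1CCC(Oc2cc(Oc3cccc(/C=C4\SC(=O)NC4=O)c3)ncn2)CC1` differs from compound 3 by isobutyl in place of tert-butyl on an oxygen next to a carbonyl group, the same change as from compound 1 to compound 2. With a single earlier instance, the expected step from compound 3 to compound 4 is a large drop, tempered because compound 3 starts from 78.3% and a drop of the full earlier size would reach a very small response; the expected step is a number 53.3 percentage points lower from compound 3 to compound 4 (beyond the scatter). Compound 4 is estimated at 25%, expected between 5% and 60%.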

Compound 4, largest response reached (Emax), in percent of the reference or control that the assay uses: 62.4%
The estimate for compound 4 lay 37.4 percentage points below the measured number, outside the stated range (above it).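

In this assay the exchange of tert-butyl for isobutyl on an oxygen next to a carbonyl group gives a number 15.9 percentage points lower from compound 3 to compound 4 (beyond the scatter) and so lowers the maximal response on the second core as well. The direction of the step therefore carries over between these two cores, but its size does not: the same change on two cores in this assay, a number 71 percentage points lower (beyond the scatter) from compound 1 to compound 2 and a number 15.9 percentage points lower (beyond the scatter) from compound 3 to compound 4, 55.1 percentage points apart, beyond the scatter of two such steps. For the compounds shown here, with only two pairs, this does not establish a general rule for the series, and it does not show whether the difference in size follows from the core itself or from the different starting values of compound 1 and compound 3.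

The compounds shown leave open how the response changes with other groups on this oxygen, such as ethyl, cyclopropylmethyl or a longer chain like n-hexyl. Also open, going by these compounds, is whether the same exchange would keep its direction on a third core, or on a piperidine nitrogen carrying an amide or a urea in place of the carbamate.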